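Aryl ether series on a shared core: cytotoxicity working notes

The source may report more compounds than this note shows. Statements on the series, on what has been measured and on what is new or still open speak of the compounds shown alone.

Measured so far:
compound 1 `COc1c(OCc2cnoc2C)cc(O)c2c(=O)cc(-c3ccccc3)oc12` — > 100000 nM
compound 2 `O=c1cc(-c2ccccc2)oc2c(OCCNCCO)c(O)cc(O)c12` — "not determined" (no result reported)
compound 3 `CN(C)CCCCOc1c(O)cc(O)c2c(=O)cc(-c3ccccc3)oc12` — > 100000 nM

In a functional assay on A549 cells (Homo sapiens) for cytotoxicity, read by MTT assay, with a stated time of 48 h (a higher number here means a weaker inhibitor, a lower number a stronger inhibitor), compound 1 gives > 100000 nM, which is a limit of the assay and not a number. Compound 3 likewise gives > 100000 nM in this assay, again a limit rather than a number. For compound 2 no result is reported in this assay. Compound 1 therefore stands at the edge of what the assay reports, with no single value to place it against any other compound; the limit of > 100000 nM in this assay, at which 2 of the 3 values shown sit, describes where two of the three shown entries sit.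

The compound to be measured is compound 4 `COc1c(OCCCN2CCCC2)cc(O)c2c(=O)cc(-c3ccccc3)oc12`. It differs from compound 1 in one place: 2-(pyrrolidin-1-yl)ethyl in place of 5-methyl-1,2-oxazol-4-yl on a saturated chain carbon bound to an oxygen on an aromatic ring.

Among the compounds with values here, no step between measured compounds is available, so the size of the step from compound 1 to compound 4 in this assay can only be set by expectation. Both shown values sit at the limit, and the change keeps the shared core intact, so no movement beyond the scatter is expected; compound 4 is expected to remain at or near the limit, with the step that the limit leaves unreadable from compound 1 to compound 4 reflecting this. The estimate for compound 4 is 150000 nM, with a range from 40000 nM to 600000 nM.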

Compound 4, half-maximal inhibitory concentration: 1390 nM
For compound 4 the middle estimate is 110-fold (2.03 log units) above the measured one; the measured number lies below the stated range.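

In this assay, 3-(pyrrolidin-1-yl)propoxy in place of (5-methyl-1,2-oxazol-4-yl)methoxy gives an at least 71-fold lower number from compound 1 to compound 4 (1.85 log units; beyond the scatter), so a change in this one place, with the shared core kept, is enough to bring the read-out off the limit. The step is one-sided, and its full size cannot be read, since its starting point is a limit and not a number, and compound 4 is the only compound shown that carries a single number: the limit of > 100000 nM in this assay, at which 2 of the 4 values shown sit.

The step also treats the change as a whole, so it does not separate the loss of the 5-methyl-1,2-oxazol-4-yl ring from the entry of the pyrrolidine ring or from the longer chain.

The compounds shown leave open how much of the step belongs to the ring nitrogen and how much to the chain: a morpholine or a piperidine on the same propoxy chain, or a cyclopentyl group with no nitrogen, would begin to separate these. They also leave open whether a shorter or longer chain carrying the same pyrrolidine ring would hold the value of compound 4 in this assay.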